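This account rests on a few compounds, and the source may have more. Where it says the series, first, only, none or still open, it means among the compounds named here.

Working notes on the series.

Compound 3 `Cc1nc2c(OCc3ccccc3)cccn2c1CC1=NCCN1` is the reference point here. In a functional assay on the whole organism with Rattus norvegicus as the target, with a stated time of 4 h, at a dose of 40 mg/kg by the intraperitoneal route (a lower number here means less inhibition, a higher number more inhibition at the dose given (going by the name of the read-out)), compound 3 gives 69%, the highest of the three numbers in hand. Its nearest neighbour is compound 2 `Cc1nc2c(OCc3ccccc3)cccn2c1CC(=O)O`, which in this assay gives 12%; the furthest is compound 1 `Cc1nc2c(OCc3ccccc3)cccn2c1C[S+](C)[O-]`, which in this assay gives 0%. All three share one core and differ only in the group on the saturated chain carbon bound to an aromatic carbon. The steps there are a number 12 percentage points higher from compound 1 to compound 2 (beyond the scatter), a number 69 percentage points higher from compound 1 to compound 3 (beyond the scatter) and a number 57 percentage points higher from compound 2 to compound 3 (beyond the scatter).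

Compound 4 `Cc1nc2c(OCc3ccccc3)cccn2c1COC(=O)c1cccnc1` is the next member, not yet measured in this assay. Against compound 3 the change is a group of 9 heavy atoms (6 carbon, 1 nitrogen, 2 oxygen; one six-membered aromatic ring with 1 hetero atom) in place of a group of 5 heavy atoms (3 carbon, 2 nitrogen; one five-membered non-aromatic ring with 2 hetero atoms), on a saturated chain carbon bound to an aromatic carbon.

For the measured compounds named here, no measured step covers the group that enters. What bears on it is that both measured steps into compound 3, a number 69 percentage points higher from compound 1 to compound 3 (beyond the scatter) and a number 57 percentage points higher from compound 2 to compound 3 (beyond the scatter), were large, and that the two compounds without the five-membered non-aromatic ring with 2 hetero atoms, compound 1 and compound 2, sit near the bottom of the range. Removing that ring is therefore expected to cost most of the read-out, and the step of a number 54 percentage points lower from compound 3 to compound 4 (beyond the scatter) is expected to be large and downward. Compound 4 is estimated at 15%, within 0% to 45%.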

Compound 4, a percentage reported as inhibition, in the whole organism at one dose (the size of the read-out at that dose, not a potency): 87%
Compound 4: middle estimate off by 72 percentage points, on the low side; measured number above the stated range.
By their numbers in this assay, from the lowest: compound 1; then compound 2; then compound 3; then compound 4.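

In this assay, the five-membered non-aromatic ring with 2 hetero atoms proves not to be needed for a high read-out on the saturated chain carbon bound to an aromatic carbon: ((pyridin-3-yl)carbonyl)oxy, which lacks that ring, gives a number 18 percentage points higher from compound 3 to compound 4 (beyond the scatter) in place of it. The low numbers of the two earlier compounds without that ring therefore do not extend to every group without it, and compound 4 goes against that pattern, with a number 75 percentage points higher from compound 2 to compound 4 (beyond the scatter) on exchange of carboxy and a number 87 percentage points higher from compound 1 to compound 4 (beyond the scatter) against the group of compound 1. Nothing available accounts for the high read-out of the entering group.

Still open, going by these compounds, is which part of ((pyridin-3-yl)carbonyl)oxy carries the read-out: an acetyloxy group, with no ring, and a benzoyloxy group, with a carbon-only aromatic ring, would separate the carbonyl-oxygen link from the pyridine ring. On these data alone, it is equally open whether a different kind of link holds the number, as in a (pyridin-3-yl)carbonylamino group, where a nitrogen stands in place of the oxygen.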